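The compounds below may be only part of what the source reports. "The series", "measured", "known", "first", "only" and "open" are said of these compounds alone.

Compound 1 `COc1cc(C)nc2n/c(=N/C(=O)c3c(-c4ccc(Cl)cc4Cl)noc3C)sn12` and compound 2 `COc1cc(OC)n2s/c(=N\C(=O)c3c(-c4ccc(Cl)cc4Cl)noc3C)nc2n1` share a fused two-ring core, while compound 3 `COc1cc(OC)nc(NC(=S)NC(=O)c2c(-c3ccc(Cl)cc3Cl)noc2C)n1` is built on a different core; how the core of compound 3 differs from that of compound 2 is not broken down here. In a functional assay on the whole organism for inhibition, with Chenopodium ficifolium as the target, with a stated time of 72 h, tested at 100 mg/L (a higher number here means more inhibition of growth at the concentration tested, a lower number less inhibition of growth), compound 1 gives 80.4%, compound 2 gives 82.7%, and compound 3 gives 78.6%. From compound 2 to compound 1 the change is methyl in place of methoxy on an aromatic carbon and it made a number 2.3 percentage points lower from compound 2 to compound 1 (within the scatter).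

Compound 4 `COc1cc(C)nc(NC(=S)NC(=O)c2c(-c3ccc(Cl)cc3Cl)noc2C)n1` arises from compound 3 by the same kind of change, (methyl in place of methoxy on an aromatic carbon); here the ring is not part of a fused system, and the place is meta to a large group rather than meta and para to a fused ring. Because the earlier step of a number 2.3 percentage points lower from compound 2 to compound 1 (within the scatter) stayed within the scatter, compound 4 is expected to change little, with an estimated step of a number 1.6 percentage points lower from compound 3 to compound 4 (within the scatter). The expected value for compound 4 is 77%, likely between 68% and 85%.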

Compound 4, percent growth inhibition at one concentration: 59.8%
Estimate against measurement, compound 4: 17.2 percentage points above; measured number below the stated range.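

In this assay, putting methyl in place of methoxy on the core of compound 3 gives a number 18.8 percentage points lower from compound 3 to compound 4 (beyond the scatter), a much larger effect than the same change has on the shared core of compound 1 and compound 2. The size of this step therefore does not carry over from one core to the other in this series: the same change on two cores in this assay, a number 2.3 percentage points lower (within the scatter) from compound 2 to compound 1 and a number 18.8 percentage points lower (beyond the scatter) from compound 3 to compound 4, 16.5 percentage points apart, beyond the scatter of two such steps. Among these compounds, with only one pair on each core, this does not show why the two steps differ or which of them a further core would resemble.

The compounds shown leave open how an amine or an ethoxy group in the same place would behave on either core. They also leave open whether chloro would follow the methyl result.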